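Piperidinylmethyl Replaces Cyano on a Whole-Organism Inhibitor

The source may hold more compounds than are shown below. What is called first, only, known or untested is meant among the compounds shown, and "the series" means these compounds.

Two compounds have been measured in a functional assay on the whole organism for inhibition, with Artemia salina as the target; a lower number here means a stronger inhibitor of growth, a higher number a weaker inhibitor of growth:
Compound 1 `CO[C@H]1C[C@H](O[Si](C)(C)C(C)(C)C)O[C@@H](C)/C1=C/CCl` gives 0.01 ug/mL.
Compound 2 `CO[C@H]1C[C@H](O[Si](C)(C)C(C)(C)C)O[C@@H](C)/C1=C/C#N` gives 0.0005 ug/mL.

For the measured compounds named here, compound 2 holds the lowest of these two numbers; the only other, compound 1, lies higher, the step a number 4.3 two-fold dilutions lower from compound 1 to compound 2 (beyond the scatter) being the single comparison available. Compound 3 `CO[C@H]1C[C@H](O[Si](C)(C)C(C)(C)C)O[C@@H](C)/C1=C/CN1CCCCC1` carries (piperidin-1-yl)methyl in place of cyano on a double-bonded chain carbon bound to a double-bonded ring carbon. Going by the values given here, the one measured step bears on this change indirectly: replacing the chloromethyl by cyano gave the large fall seen in a number 4.3 two-fold dilutions lower from compound 1 to compound 2 (beyond the scatter), so removing the cyano again in compound 3 is expected to give a rise, estimated as a number 5.3 two-fold dilutions higher from compound 2 to compound 3 (beyond the scatter). Compound 3 is therefore expected to give 0.02 ug/mL, within a range from 0.002 ug/mL to 0.2 ug/mL.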

Compound 3, minimum inhibitory concentration: 0.01 ug/mL
Compound 3: middle estimate off by one two-fold dilution, on the high side, and the stated range covers the measured number.
By their numbers in this assay, from the lowest: compound 2; then compounds 1 and 3 (each within the scatter of the next).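

In this assay, for the compounds shown here, compound 2 now stands apart from two different replacements: (piperidin-1-yl)methyl in place of cyano gives a number 4.3 two-fold dilutions higher from compound 2 to compound 3 (beyond the scatter), a step of the same size as the one from the chloromethyl compound. Piperidin-1-yl in place of chloro on the saturated chain carbon gives no change at the digits printed from compound 1 to compound 3 (within the scatter), so these two groups are not told apart here, although only one of them contains a ring.

As far as these compounds go, whether a carboxylic acid, an amide or a primary amine at this place would come near the cyano compound stays open. From the compounds shown here alone, what sets the cyano group apart also stays open, as no supporting evidence is available.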